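This account rests on a few compounds, and the source may have more. Where it says the series, first, only, none or still open, it means among the compounds named here.

Compound 1, `CCCSc1nc(N)c2nc(O)n(Cc3ccccc3)c2n1`, gives 0.1 mg/kg in a functional assay on the whole organism for activation, with Mus musculus as the target; a lower number here means that less compound is needed, a higher number that more compound is needed for the effect.
Compound 2, `CCCCNc1nc(N)c2nc(O)n(Cc3ccccc3)c2n1`, gives 0.1 mg/kg.
Compound 3, `CCCCCOc1nc(N)c2nc(O)n(Cc3ccccc3)c2n1`, gives 0.3 mg/kg.

Compound 3 stands at the highest number of the three, so it needs the most compound for the effect; the steps of a 3.0-fold higher number from compound 1 to compound 3 (0.48 log units; beyond the scatter) and a 3.0-fold higher number from compound 2 to compound 3 (0.48 log units; beyond the scatter) are both modest. Compound 4, `CCCc1nc(N)c2nc(O)n(Cc3ccccc3)c2n1`, differs from compound 3 by propyl in place of pentyloxy on an aromatic carbon. Within the data shown here, no measured step takes away the oxygen of this chain; the two steps into compound 3 only exchange one chain for another and stay modest, so there is no firm guide to a change in this assay. Close to compound 3 is where compound 4 is expected to sit, at 0.3 mg/kg, within 0.1 mg/kg to 1 mg/kg. The step expected is no change at the digits printed from compound 3 to compound 4 (within the scatter).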

Compound 4, minimum effective dose: 3 mg/kg
Estimate against measurement, compound 4: 10-fold (1.00 log units) below; measured number outside the range, above it.
By their numbers in this assay, from the lowest: compounds 1 and 2 (each within the scatter of the next); then compound 3; then compound 4.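

In this assay, this position proves far less forgiving than the first three compounds suggested: swapping one chain for another had cost little, but a chain attached directly through carbon gives a 10-fold higher number from compound 3 to compound 4 (1.00 log units; beyond the scatter). The larger changes are a 30-fold higher number from compound 2 to compound 4 (1.48 log units; beyond the scatter) and a 30-fold higher number from compound 1 to compound 4 (1.48 log units; beyond the scatter), and the last of these keeps a three-carbon chain and loses only the sulfur that linked it to the core. Nothing available here explains this loss. From the compounds shown here alone, it remains open whether a longer pentyl chain on the same carbon would recover the effect, and whether propyloxy or propylamino would match the propylsulfanyl group.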